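Working notes: from compound 1 to compound 4

This account rests on a few compounds, and the source may have more. Where it says the series, first, only, none or still open, it means among the compounds named here.

- compound 1 `C[C@H](Oc1ccc2ncc(/C=C/C(=O)O)c(C3CC3)c2c1)c1c(Cl)ccc(N)c1Cl` gives 2.8 in a physicochemical assay for lipophilicity, using the shake flask method; on this read-out higher numbers stand for higher lipophilicity and lower numbers for lower lipophilicity
- compound 2 `C[C@H](Oc1ccc(/C=C/C(=O)O)cc1)c1c(Cl)ccc(F)c1Cl` gives 2.8 in the same measurement
- compound 3 `CC(Oc1ccc2ncc(/C=C/C(=O)O)cc2c1)C1CCCCC1` gives 3 in the same measurement

Compound 1 at 2.8 is level with compound 2 at 2.8 and compound 3 at 3 lies within the usual scatter of both of them. The three numbers therefore form one group, and none of them can be ranked against the others.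

Compound 4 `Cc1cnn(C)c1[C@H](C)Oc1ccc2ncc(/C=C/C(=O)O)c(C3CC3)c2c1` is still unmeasured and shares the core of compound 1. Among the compounds with values here, the only change is a group of 7 heavy atoms (5 carbon, 2 nitrogen; one five-membered aromatic ring with 2 hetero atoms) in place of a group of 9 heavy atoms (6 carbon, 1 nitrogen, 2 chlorine; one six-membered aromatic ring of carbon only), on a saturated chain carbon bound to an oxygen on an aromatic ring and a saturated chain carbon with the rest of compound 1 kept. The entering group is 1,4-dimethyl-1H-pyrazol-5-yl, and it carries no chlorine.

Within the data shown here, no measured pair in this set differs in one place, so no measured step supports the size of this change. The expectation rests only on the structural count and on compound 1 at 2.8 as the starting point. A clear downward step is expected in this assay and the estimate (a number 0.90 log units lower from compound 1 to compound 4 (beyond the scatter)) lies beyond the usual scatter. For compound 4 the estimated value is 1.9 with an expected range from 1.3 to 2.5 in this assay until a measurement is available.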

Compound 4, distribution coefficient: 0.9
The estimate for compound 4 lay 1.00 log units above the measured number; the whole stated range lies above it.
By their numbers in this assay, from the lowest: compound 4; then compounds 1, 2 and 3 (each within the scatter of the next).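

In this assay, the group on the saturated chain carbon bound to an oxygen on an aromatic ring and a saturated chain carbon turns out to carry real weight: with the core of compound 1 kept, 1,4-dimethyl-1H-pyrazol-5-yl in place of the six-membered aromatic ring of carbon only, with its two chlorine atoms, gives a number 1.90 log units lower from compound 1 to compound 4 (beyond the scatter). Within the data shown here, the earlier compounds stood within the scatter of one another and no pair among them differed in one place, so this is the first step that can be read, and it shows that a single change at this position can move the read-out well beyond the scatter. Nothing measured here bears on the reason for the size of this step.

The swap changes the ring type, the chlorine atoms and the substituents together, so the compounds shown leave open how the step divides among them. From the compounds shown here alone, an unsubstituted phenyl ring or a pyridine ring at the same place on the shared core would separate these contributions, and whether the step carries over to another core also remains open.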